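This account rests on a few compounds, and the source may have more. Where it says the series, first, only, none or still open, it means among the compounds named here.

Three compounds share one core and differ only in the aromatic group attached to it. Compound 1 `CCOC(=O)CCCCCOc1cccc(CN(C(=O)c2ccc(-c3ccncc3)cc2)C(C)C)c1` carries pyridin-4-yl, compound 2 `CCOC(=O)CCCCCOc1cccc(CN(C(=O)c2ccc(-c3cccc(-c4ccccc4)c3)cc2)C(C)C)c1` carries 3-phenylphenyl, and compound 3 `CCOC(=O)CCCCCOc1cccc(CN(C(=O)c2ccc(-c3cccnc3)cc2)C(C)C)c1` carries pyridin-3-yl. Each was tested in an ADME assay on BJ cells (Homo sapiens) for cytotoxicity, read by CellTiter-Glo and resazurin assay, with a stated time of 72 h; a higher number here means that more compound is needed for the effect, a lower number that less compound is needed. In this assay compound 1 gives only a limit, > 26000 nM. Compound 2 likewise gives only a limit, > 26000 nM. Compound 3 also gives only a limit, > 26000 nM. Compound 3 therefore cannot be placed higher or lower than its two companions; the steps a step that the two limits leave unreadable from compound 1 to compound 3 and a step that the two limits leave unreadable from compound 2 to compound 3 stay unreadable, as does a step that the two limits leave unreadable from compound 1 to compound 2, because of the limit of > 26000 nM in this assay, at which 3 of the 3 values shown sit.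

Compound 4 `CCOC(=O)CCCCCOc1cccc(CN(C(=O)c2ccc(-c3cccc(OCC(C)C)c3)cc2)C(C)C)c1` is not yet measured. It differs from compound 3 in one place: 3-(isobutoxy)phenyl in place of pyridin-3-yl on an aromatic carbon. The two measured steps that end at compound 3 bear on this change only in that exchanging one aromatic group for another at this position never brought a compound under the limit. Within the data shown here, no step of readable size exists here, so the step expected from the change, a step that the limit leaves unreadable from compound 3 to compound 4, amounts to the limit holding again. Compound 4 is accordingly estimated to show 30000 nM in this assay, within a range from 12000 nM to 80000 nM, most probably once more as a limit.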

Compound 4, half-maximal effective concentration: > 26000 nM
Compound 4: only a limit was reported; the forecaster's own chance of this, stated with the estimate: 75%; the middle value lies beyond the limit too.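

The steps from compound 1, compound 2 and compound 3 to compound 4 cannot be read, because none of these compounds gives more than a limit in this assay: the limit of > 26000 nM in this assay, at which 4 of the 4 values shown sit.

The compounds shown leave open how compound 1, compound 2, compound 3 and compound 4 rank against one another in this assay, since none has a measured number.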